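Aryl substituent changes in an anilide series and edema inhibition

The compounds below may be only part of what the source reports. "The series", "measured", "known", "first", "only" and "open" are said of these compounds alone.

Measured compounds:
compound 1, `COc1cc2c(cc1OC)C(CC(=O)Nc1ccccc1)CC2`, 32%
compound 2, `COc1cc2c(cc1OC)C(CC(=O)Nc1cccc(Cl)c1)CC2`, 28%
compound 3, `COc1cc2c(cc1OC)C(CC(=O)Nc1cccc(C)c1)CC2`, 29%

In a functional assay on the whole organism (strain Wistar) for inhibition, with Rattus norvegicus as the target, read by paw edema, with a stated time of 2 h, at a dose of 100 mg/kg (a higher number here means more inhibition at the dose given (going by the name of the read-out), a lower number less inhibition), compound 3 gives 29%, the second highest of three numbers; its nearest neighbour is compound 2, with a number 1 percentage points higher from compound 2 to compound 3 (within the scatter), and its furthest is compound 1, with a number 3 percentage points lower from compound 1 to compound 3 (within the scatter). Compound 4, `COc1ccccc1NC(=O)CC1CCc2cc(OC)c(OC)cc21`, differs from compound 3 by 2-methoxyphenyl in place of 3-methylphenyl on an amide-type nitrogen.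

The measured steps that bear on this change are those altering the aromatic ring on the amide nitrogen: a number 4 percentage points lower from compound 1 to compound 2 (within the scatter), a number 3 percentage points lower from compound 1 to compound 3 (within the scatter) and a number 1 percentage points higher from compound 2 to compound 3 (within the scatter), all within the scatter. Within the data shown here, no measured step covers a methoxy group, so the expectation rests on these alone, and no step beyond the scatter is expected in this assay. Compound 4 is therefore estimated to give 30%, between 18% and 42%, a step of a number 1 percentage points higher from compound 3 to compound 4 (within the scatter).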

Compound 4, a percentage reported as inhibition, in the whole organism at one dose (the size of the read-out at that dose, not a potency): 16%
Compound 4: the middle estimate sits 14 percentage points above what was measured; the whole stated range lies above it.
By their numbers in this assay, from the lowest: compound 4; then compounds 2, 3 and 1 (each within the scatter of the next).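

In this assay, among these compounds, the 2-methoxyphenyl group on the amide-type nitrogen gives the first steps beyond the scatter in this set, with a number 13 percentage points lower from compound 3 to compound 4 (beyond the scatter) against 3-methylphenyl, a number 12 percentage points lower from compound 2 to compound 4 (beyond the scatter) against 3-chlorophenyl and a number 16 percentage points lower from compound 1 to compound 4 (beyond the scatter) against the unsubstituted ring. The read-out at this position therefore does respond to the aryl group, which the chloro and methyl changes did not show. Nothing available explains this drop.

From the compounds shown here alone, whether it follows the methoxy group itself or its place on the ring remains open; 3-methoxyphenyl and 2-methylphenyl would separate the two. Going by these compounds, how a carboxylic acid or an amine on this ring would read also remains open.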